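Swapping (pyridin-4-yl)sulfanyl for methoxy in compound 4

The compounds below may be only part of what the source reports. "The series", "measured", "known", "first", "only" and "open" are said of these compounds alone.

Compound 1 `Cc1c(C)c2c(c(N)c1N)CC(C)(C)O2`: > 50 mg/kg (a limit)
Compound 2 `Cc1c(C)c2c(c(C)c1N)CC(C)(CSc1ccncc1)O2`: 19.9 mg/kg
Compound 3 `Cc1c(C)c2c(c(C)c1N)CC(C)(CSCc1ccccc1)O2`: 32 mg/kg

All three were tested in a functional assay on the whole organism with Mus musculus as the target; on this read-out higher numbers stand for an effect only at larger amounts of compound and lower numbers for an effect already at smaller amounts. For the measured compounds named here, compound 2 and compound 3 give the only true numbers, and they do not separate: a 1.6-fold higher number from compound 2 to compound 3 (0.21 log units; within the scatter). Compound 4 `COCC1(C)Cc2c(C)c(N)c(C)c(C)c2O1` carries a single change from compound 2: methoxy in place of (pyridin-4-yl)sulfanyl on a saturated chain carbon bound to a saturated ring carbon. Going by the values given here, the one measured step changes only the group on the sulfur, so it says little about removing that sulfur. Compound 1, which also lacks sulfur but differs elsewhere too, gives only a limit of the assay, > 50 mg/kg. That limit tilts the expectation modestly upward, and the estimated change is a 1.5-fold higher number from compound 2 to compound 4 (0.18 log units; within the scatter). For compound 4 the expected value is 30 mg/kg, with an estimated range of 12 mg/kg to 70 mg/kg.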

Compound 4, dose for 50% inhibition: 20.1 mg/kg
Estimate against measurement, compound 4: 1.5-fold (0.17 log units) above; the measured number falls inside the stated range.
By their numbers in this assay, from the lowest: compounds 2, 4 and 3 (each within the scatter of the next). At a limit, above all of these: compound 1.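

In this assay, replacing the (pyridin-4-yl)sulfanyl group with the much smaller methoxy group leaves no readable difference: a 1.0-fold higher number from compound 2 to compound 4 (0.00 log units; within the scatter). The earlier step changed only the group on the sulfur, whereas this one shows that neither the sulfur nor the aromatic ring is needed at this place to keep a number in this range. The data shown give no cause for this result.

On these data alone, whether an amine, a carboxylic acid or a longer chain on the same saturated chain carbon would also fit remains open.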